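The source may report more compounds than this note shows. Statements on the series, on what has been measured and on what is new or still open speak of the compounds shown alone.

Values in an assay (Populus sieboldii x Populus grandidentata) for inhibition of Trans-cinnamate 4-monooxygenase (Populus kitakamiensis), with a stated time of 60 min; on this read-out lower numbers stand for stronger inhibition and higher numbers for weaker inhibition:
compound 1 `Sc1nnc(-c2ccco2)o1`: 5900 nM
compound 2 `Sc1nnc(-c2cccc(Cl)c2)o1`: 210 nM

Of the two numbers in this assay, compound 2 has the lower one; the nearest neighbour is compound 1, whose number is higher by a margin beyond the scatter, so compound 2 stands as the stronger of the two on this read-out. Compound 3 `Fc1cccc(-c2nnc(S)o2)c1` has not been measured in this assay. It differs from compound 2 in one place: fluoro in place of chloro on an aromatic carbon, which is fluoro in place of chloro on an aromatic carbon. Among the compounds with values here, no step between measured compounds bears on a swap of this kind, so the size of the step is uncertain. A modest loss of inhibition is expected, of about a 2.1-fold higher number from compound 2 to compound 3 (0.33 log units; beyond the scatter), though a step within the scatter cannot be excluded. For compound 3 the half-maximal inhibitory concentration is expected to be 450 nM, within 150 nM to 1400 nM.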

Compound 3, half-maximal inhibitory concentration: 130 nM
Compound 3: middle estimate off by 3.5-fold (0.54 log units), on the high side; measured number below the stated range.
By their numbers in this assay, from the lowest: compounds 3 and 2 (each within the scatter of the next); then compound 1.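

At this place, on an aromatic carbon of the six-membered aromatic ring, fluoro in place of chloro gives a 1.6-fold lower number from compound 2 to compound 3 (0.21 log units; within the scatter) in this assay, so the two halogens cannot be told apart on this read-out. Inhibition at this level therefore does not require chloro specifically, since compound 3, with fluoro, gives 130 nM. Nothing measured on these compounds speaks to why this swap leaves the number within the scatter.

From the compounds shown here alone, whether a hydrogen, a methoxy group, a trifluoromethyl group or an amine at the same place would keep inhibition at this level stays open. Going by these compounds, it is also open whether fluoro or chloro on another carbon of the same ring would give numbers like these.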